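The compounds below may be only part of what the source reports. "The series", "measured", "known", "first", "only" and "open" are said of these compounds alone.

In a functional assay on CCRF-CEM cells (Homo sapiens) for antiproliferative activity, read by MTT assay, with a stated time of 48 h (on this read-out lower numbers stand for an effect already at smaller amounts and higher numbers for an effect only at larger amounts of compound), compound 1 `COC(=O)c1[nH]c2cc(OC)ccc2c1-c1ccc(Br)cc1` gives 330 nM. Compound 2 `CCc1c(C(=O)OC)[nH]c2cc(OC)ccc12` stands only at a limit of this assay, > 100000 nM. Compound 3 `COC(=O)c1[nH]c2cc(OC)ccc2c1C(C)C` differs from compound 2 by methyl in place of hydrogen on a saturated chain carbon bound to an aromatic carbon and a saturated chain carbon, which turns ethyl to isopropyl. Within the data shown here, the one measured step bearing on this is large: an at least 300-fold higher number from compound 1 to compound 2 (2.48 log units; beyond the scatter). That step replaced 4-bromophenyl, and compound 3 does not bring it back, so no recovery of that size is expected. The expected change is modest and may not be resolved at the limit, an at least 1.4-fold lower number from compound 2 to compound 3 (0.15 log units; that floor lies within the scatter). For compound 3 the estimated value is 70000 nM, with an expected range from 15000 nM to 150000 nM.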

Compound 3, half-maximal effective concentration: > 100000 nM
Compound 3 was reported as a limit; the forecaster's own chance of this, stated with the estimate: 70%; at least 1.4-fold (0.15 log units) between middle value and limit.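

In this assay, isopropyl on this aromatic carbon, like ethyl, leaves no readable activity, so the loss seen on replacing 4-bromophenyl is not confined to a single chain: an at least 300-fold higher number from compound 1 to compound 3 (2.48 log units; beyond the scatter). The step from compound 2 to compound 3 cannot be read, since both compounds sit at the same limit of the assay: the limit of > 100000 nM in this assay, at which 2 of the 3 values shown sit.

The compounds shown leave open whether any other group at this carbon restores a readable value, such as plain phenyl, 4-chlorophenyl or an amine. They also leave open how much of the activity of compound 1 depends on the bromine.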